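The source may report more compounds than this note shows. Statements on the series, on what has been measured and on what is new or still open speak of the compounds shown alone.

Of the compounds shown here, three built on one shared core have been tested in a functional assay on HCT-116 cells (Homo sapiens) for inhibition, read by MTT assay, with a stated time of 48 h; on this read-out lower numbers stand for stronger inhibition and higher numbers for weaker inhibition. Compound 1 `COc1ccc(CN(C(=O)C(C)Br)c2cc(OC)c(OC)c(OC)c2)cc1O` gives 140 nM, compound 2 `COc1ccc(CN(C(=O)CO)c2cc(OC)c(OC)c(OC)c2)cc1O` gives 520 nM, and compound 3 `COc1ccc(CN(C(=O)CN=[N+]=[N-])c2cc(OC)c(OC)c(OC)c2)cc1O` gives 410 nM. Compound 3 thus stands second highest of the three numbers: the step of a 1.3-fold lower number from compound 2 to compound 3 (0.10 log units; within the scatter) lies within the scatter, while the step of a 2.9-fold higher number from compound 1 to compound 3 (0.47 log units; beyond the scatter) is beyond it, so compound 3 sits close to compound 2 and apart from compound 1.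

Compound 4 `C=CC(=O)N(Cc1ccc(OC)c(O)c1)c1cc(OC)c(OC)c(OC)c1` is the next step: vinyl in place of azidomethyl on a carbonyl carbon. Of the measured steps, those that alter the group on the carbonyl carbon bear on it. The steps of a 3.7-fold higher number from compound 1 to compound 2 (0.57 log units; beyond the scatter) and a 2.9-fold higher number from compound 1 to compound 3 (0.47 log units; beyond the scatter) were modest shifts in the same direction, and the step of a 1.3-fold lower number from compound 2 to compound 3 (0.10 log units; within the scatter) barely moved the number. Among the measured compounds shown here, no measured step contains the vinyl group, so the direction remains uncertain. A step of modest size in either direction, or none beyond the scatter, is the expectation, and the estimated step is a 1.6-fold lower number from compound 3 to compound 4 (0.21 log units; within the scatter). Compound 4 is therefore expected to give about 250 nM in this assay, within a range from 90 nM to 700 nM.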

Compound 4, half-maximal inhibitory concentration: 98 nM
Estimate against measurement, compound 4: 2.6-fold (0.41 log units) above; low and high end bracket the measured number.
By their numbers in this assay, from the lowest: compounds 4 and 1 (each within the scatter of the next); then compounds 3 and 2 (each within the scatter of the next).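

Vinyl on the carbonyl carbon gives a 4.2-fold lower number from compound 3 to compound 4 (0.62 log units; beyond the scatter) when it replaces azidomethyl and a 5.3-fold lower number from compound 2 to compound 4 (0.72 log units; beyond the scatter) when it replaces hydroxymethyl, so this position can still respond strongly to a change of group. Replacing 1-bromoethyl with vinyl gives a 1.4-fold lower number from compound 1 to compound 4 (0.15 log units; within the scatter) and stays within the scatter, which places these two different groups level with each other and apart from azidomethyl and hydroxymethyl. On this core, then, the lower numbers do not require a bromine atom, since vinyl carries none.

Nothing at hand explains why vinyl and 1-bromoethyl fall together. Going by these compounds, it also remains open how a chloromethyl group, an amine or a longer chain on the carbonyl carbon would compare with these four.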